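This account rests on a few compounds, and the source may have more. Where it says the series, first, only, none or still open, it means among the compounds named here.

Compound 1 `CSc1ccc(C(=O)/C=C/c2ccc([N+](=O)[O-])o2)cc1`: 13100 nM
Compound 2 `O=C(/C=C/c1ccc([N+](=O)[O-])s1)c1ccc(-n2ccnc2)cc1`: 23400 nM

In an ADME assay on THP-1 cells (Homo sapiens) for cytotoxicity, read by resazurin assay, with a stated time of 72 h (a higher number here means that more compound is tolerated, a lower number that less compound is tolerated), compound 2 gives 23400 nM, which lies within the scatter of compound 1 at 13100 nM. Compound 3 `CSc1ccc(C(=O)/C=C/c2ccc([N+](=O)[O-])s2)cc1` has methylsulfanyl in place of 1H-imidazol-1-yl on an aromatic carbon. Going by the values given here, no measured step shows the effect of this exchange. Compound 1, which also carries methylsulfanyl, gives 13100 nM, so only a small downward shift, within the scatter of this assay, is expected. The estimated change is a 1.6-fold lower number from compound 2 to compound 3 (0.19 log units; within the scatter). The expected value for compound 3 is 15000 nM, with an estimated range of 6500 nM to 33000 nM.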

Compound 3, half-maximal cytotoxic concentration: 8560 nM
The estimate for compound 3 lay 1.8-fold (0.24 log units) above the measured number, and the stated range covers the measured number.
By their numbers in this assay, from the lowest: compounds 3, 1 and 2 (each within the scatter of the next, the first and the last beyond it).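

Going by these compounds alone, the exchange of 1H-imidazol-1-yl for methylsulfanyl on this aromatic carbon, para to a large group, gives the first step between compounds differing in one place: in this assay there is a 2.7-fold lower number from compound 2 to compound 3 (0.44 log units; beyond the scatter), beyond the scatter. At this position, therefore, the exchange lowers the tolerated concentration modestly. No measurement shown accounts for this shift. As far as these compounds go, whether an amine, a carboxylic acid or a longer alkylsulfanyl chain on this carbon would stand nearer compound 2 or compound 3 remains open. So does whether the same exchange would shift the number similarly on the core of compound 1.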